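Working notes: amine variation from compound 3 to compound 4

This account rests on a few compounds, and the source may have more. Where it says the series, first, only, none or still open, it means among the compounds named here.

Measured in a functional assay on SK-BR-3 cells (Homo sapiens) for antiproliferative activity; a lower number here means a stronger inhibitor, a higher number a weaker inhibitor:
- compound 1 `CC(C)=CCc1cc(C(=O)Nc2cc3ccc(OCC4CCCNC4)c(C)c3oc2=O)ccc1O`: 600 nM
- compound 2 `CCNCCCOc1ccc2cc(NC(=O)c3ccc(O)c(CC=C(C)C)c3)c(=O)oc2c1C`: 720 nM
- compound 3 `CCN(C)CCCOc1ccc2cc(NC(=O)c3ccc(O)c(CC=C(C)C)c3)c(=O)oc2c1C`: 730 nM

Not yet measured: compound 4 `CC(C)=CCc1cc(C(=O)Nc2cc3ccc(OCCCN(C)C(C)C)c(C)c3oc2=O)ccc1O`.

Compound 3 cannot be separated from the other two compounds on these numbers. The measured steps are a 1.0-fold higher number from compound 2 to compound 3 (0.01 log units; within the scatter) and a 1.2-fold higher number from compound 1 to compound 3 (0.09 log units; within the scatter), and the remaining pair gives a 1.2-fold higher number from compound 1 to compound 2 (0.08 log units; within the scatter).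

The next change is methyl in place of hydrogen on a saturated chain carbon bound to an amine nitrogen and a saturated chain carbon. Put another way, ethyl becomes isopropyl, a methyl in place of hydrogen on a saturated chain carbon bound to an amine nitrogen and a saturated chain carbon.

For the measured compounds named here, no measured step makes this exact change. Going by the values given here, the closest precedent is the added methyl on the amine nitrogen, a 1.0-fold higher number from compound 2 to compound 3 (0.01 log units; within the scatter). The wider replacement of piperidin-3-yl also bears on it, a 1.2-fold higher number from compound 1 to compound 3 (0.09 log units; within the scatter). All three compounds stay within the scatter despite these amine changes, and none goes against that reading, though three compounds are a narrow base. No step beyond the scatter is therefore expected in this assay, and no direction is favoured.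

The expected step is no change at the digits printed from compound 3 to compound 4 (within the scatter). Compound 4 is estimated at 730 nM, with an expected range of 400 nM to 1300 nM.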

Compound 4, half-maximal inhibitory concentration: 570 nM
Compound 4: the middle estimate sits 1.3-fold (0.11 log units) above what was measured, within the range that was stated.
By their numbers in this assay, from the lowest: compounds 4, 1, 2 and 3 (each within the scatter of the next).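

Working notes on the amine end of the series, read in this assay: ethyl to isopropyl is the first change shown on the saturated chain carbon bound to the amine nitrogen, rather than on the nitrogen itself, and a 1.3-fold lower number from compound 3 to compound 4 (0.11 log units; within the scatter) places this carbon alongside the nitrogen as a site where an added methyl does not separate the compounds. The wider changes agree: isopropyl(methyl)amino in place of ethylamino gives a 1.3-fold lower number from compound 2 to compound 4 (0.10 log units; within the scatter) and the open-chain 2-(isopropyl(methyl)amino)ethyl in place of piperidin-3-yl gives a 1.1-fold lower number from compound 1 to compound 4 (0.02 log units; within the scatter), so neither the branched group on the nitrogen nor the ring form of the amine distinguishes these four compounds. No supporting measurement is available to explain why these steps remain so small.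

Still open, from the compounds shown here alone, is whether this holds for larger groups on the nitrogen, such as tert-butyl or cyclohexyl, or for a morpholine in place of the amine. A carboxylic acid or an amide at the chain end, and a longer chain carrying the same isopropyl(methyl)amino group, would test the same end of the molecule more severely.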